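Swapping bromo for methyl on the pendant phenyl ring

The compounds below may be only part of what the source reports. "The series", "measured", "known", "first", "only" and "open" are said of these compounds alone.

Going by the values given here, only two compounds have been measured in a functional assay on HeLa cells (Homo sapiens) for cytotoxicity, with a stated time of 72 h; a higher number here means a weaker inhibitor, a lower number a stronger inhibitor. Compound 2 `O=Cc1c(-c2ccc(Br)cc2)nc2sc(Cc3ccc(Cl)cc3)nn12` gives 4200 nM in this assay, the lowest of the two numbers. Among the compounds with values here, its single neighbour, compound 1 `O=Cc1c(-c2ccc(F)cc2)nc2sc(Cc3ccc(Cl)cc3)nn12`, carries fluoro where compound 2 carries bromo, and in this assay compound 1 gives 20000 nM. Within the data shown here, the one measured step is a 4.8-fold lower number from compound 1 to compound 2 (0.68 log units; beyond the scatter).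

Compound 3 `Cc1ccc(-c2nc3sc(Cc4ccc(Cl)cc4)nn3c2C=O)cc1` has not yet been measured. It differs from compound 2 in one place: methyl in place of bromo on an aromatic carbon. Among the measured compounds shown here, the only measured step that bears on this spot is a 4.8-fold lower number from compound 1 to compound 2 (0.68 log units; beyond the scatter), which shows that exchanging one halogen for another at this place moved the number modestly. Methyl is neither of those groups, so a step of similar or smaller size, in either direction, seems the most that can be read from it; a modest rise in the number is taken as the central guess. Compound 3 is expected to give 7000 nM, with a range from 2500 nM to 20000 nM. That estimate corresponds to an expected step of a 1.7-fold higher number from compound 2 to compound 3 (0.22 log units; within the scatter).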

Compound 3, half-maximal inhibitory concentration: 21000 nM
Compound 3: the middle estimate sits 3.0-fold (0.48 log units) below what was measured; the measured number lies above the stated range.
By their numbers in this assay, from the lowest: compound 2; then compounds 1 and 3 (each within the scatter of the next).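

In this assay, methyl in place of bromo on the phenyl ring gives a 5.0-fold higher number from compound 2 to compound 3 (0.70 log units; beyond the scatter) and so shows that the bromo compound stands apart from a non-halogen group as well as from fluoro, even though methyl and bromo each count as one heavy atom. Fluoro and methyl cannot be separated at this place, since the change between them gives a 1.1-fold higher number from compound 1 to compound 3 (0.02 log units; within the scatter); among these three compounds, only compound 2 has a number beyond the scatter of the others, which makes it the strongest inhibitor of the set. Nothing available explains why bromo behaves differently from the other two groups.

The compounds shown leave open whether bromo is a special case at this place or whether chloro, iodo, trifluoromethyl, methoxy, an amine or a carboxylic acid would give a similarly low number. On these data alone, the rest of the molecule is the same in all three compounds, so it also remains open whether the gain from bromo would survive a change elsewhere on the shared core.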